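The compounds below may be only part of what the source reports. "The series", "measured", "known", "first", "only" and "open" are said of these compounds alone.

Working notes on the series

Of the compounds shown here, three have been measured in a functional assay on KB cells (Homo sapiens) for cytotoxicity, read by MTT assay, with a stated time of 48 h; a lower number here means a stronger inhibitor, a higher number a weaker inhibitor. Compound 1, `CCn1cc(-c2nc3ccccc3[nH]2)c(=O)c2cc(F)c(N3CCNCC3)nc21`, gives 2000 nM and stands lowest of the three. Compound 2, `CCn1cc(-c2nc3ccccc3[nH]2)c(=O)c2cc(F)c(N3CCN(C)CC3)cc21`, gives 36700 nM in this assay, and compound 3, `CCn1cc(-c2nc3ccccc3o2)c(=O)c2cc(F)c(N3CCN(C)CC3)cc21`, gives 87400 nM. The difference between the core of compound 1 and the core of compound 2 is not broken down here; their values simply show compound 1 well below compound 2.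

Within the measured set one single-point change is available: 1,3-benzoxazol-2-yl in place of 1H-benzimidazol-2-yl on an aromatic carbon. That change gave a 2.4-fold higher number from compound 2 to compound 3 (0.38 log units; beyond the scatter), a modest but real loss.

Compound 4, `CCn1cc(-c2nc3ccccc3o2)c(=O)c2cc(F)c(N3CCNCC3)nc21`, has not yet been measured. It is related to compound 1 by 1,3-benzoxazol-2-yl in place of 1H-benzimidazol-2-yl on an aromatic carbon. The place of this change is described in the same words as for the pair of compound 2 and compound 3, so the change is the same kind of change, now made on the core of compound 1 rather than the core of compound 2. Going by the values given here, whether the step transfers across cores cannot be checked from the three numbers available; the pair from compound 2 to compound 3 is the only precedent.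

Resting on that precedent, the step expected from compound 1 to compound 4 in this assay is a 2.4-fold higher number from compound 1 to compound 4 (0.38 log units; beyond the scatter), close in size to a 2.4-fold higher number from compound 2 to compound 3 (0.38 log units; beyond the scatter). Compound 4 is therefore estimated at 4800 nM, with an expected range from 2000 nM to 12000 nM.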

Compound 4, half-maximal inhibitory concentration: 11700 nM
The estimate for compound 4 lay 2.4-fold (0.39 log units) below the measured number, within the range that was stated.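

In this assay, 1,3-benzoxazol-2-yl in place of 1H-benzimidazol-2-yl on the core of compound 1 gave a 5.9-fold higher number from compound 1 to compound 4 (0.77 log units; beyond the scatter). Set beside the earlier step, the change raises the number on both cores, and the two sizes cannot be told apart: the same change on two cores in this assay, a 2.4-fold higher number (0.38 log units; beyond the scatter) from compound 2 to compound 3 and a 5.9-fold higher number (0.77 log units; beyond the scatter) from compound 1 to compound 4, 2.5-fold (0.39 log units) apart, within the scatter of two such steps. This supports carrying the direction and rough size of the change between these two cores, but with a single pair on each core it does not establish a fixed size for the step, a real dependence on the core, or any behaviour on a further core.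

The compounds shown leave open how the parts of the difference between the core of compound 1 and the core of compound 2 contribute, since no pair here isolates any one of them. They also leave open whether the number at this aromatic carbon would stay in the same region with a different kind of group there, such as a carboxylic acid or a simple amide, since only 1H-benzimidazol-2-yl and 1,3-benzoxazol-2-yl are compared at this place.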